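Swapping 3-nitrophenyl for 3,4,5-trimethoxyphenyl

The compounds below may be only part of what the source reports. "The series", "measured", "known", "first", "only" and "open" are said of these compounds alone.

Measured in a functional assay on HepG2 cells (Homo sapiens) for cytotoxicity, read by MTT assay, with a stated time of 24 h; a higher number here means a weaker inhibitor, a lower number a stronger inhibitor:
Compound 1 `COc1cc(/C=C2\CN(S(=O)(=O)c3ccc(NC(C)=O)cc3)C/C(=C\c3cc(OC)c(OC)c(OC)c3)C2=O)cc(OC)c1OC`: 3890 nM
Compound 2 `CC(=O)Nc1ccc(S(=O)(=O)N2C/C(=C\c3cccc([N+](=O)[O-])c3)C(=O)/C(=C/c3ccccc3F)C2)cc1`: 8800 nM

Compound 2, at 8800 nM, has the higher of the two numbers, which makes it the weaker inhibitor of the pair. Its gap to compound 1 lies beyond the usual scatter. Compound 3 `COc1cc(/C=C2\CN(S(=O)(=O)c3ccc(NC(C)=O)cc3)C/C(=C\c3ccccc3F)C2=O)cc(OC)c1OC` has 3,4,5-trimethoxyphenyl in place of the 3-nitrophenyl of compound 2, on a double-bonded chain carbon bound to a double-bonded ring carbon (3,4,5-trimethoxyphenyl in place of 3-nitrophenyl on a double-bonded chain carbon bound to a double-bonded ring carbon). Among the compounds with values here, no measured pair isolates this change, and compound 1 differs from compound 2 in more than one place. Still, compound 1, which carries 3,4,5-trimethoxyphenyl, gives 3890 nM, so a modest drop toward stronger inhibition is expected in this assay, perhaps hardly beyond the scatter. The estimated change is a 1.6-fold lower number from compound 2 to compound 3 (0.20 log units; within the scatter). Compound 3 is estimated at 5500 nM, with an expected range from 2500 nM to 12000 nM.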

Compound 3, half-maximal inhibitory concentration: 4750 nM
Compound 3: the middle estimate sits 1.2-fold (0.06 log units) above what was measured; measured number inside the range.
By their numbers in this assay, from the lowest: compounds 1, 3 and 2 (each within the scatter of the next, the first and the last beyond it).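

In this assay, 3,4,5-trimethoxyphenyl in place of 3-nitrophenyl on a double-bonded chain carbon bound to a double-bonded ring carbon can now be read on its own, and it gives a 1.9-fold lower number from compound 2 to compound 3 (0.27 log units; within the scatter). The same kind of position also yields a second single exchange, 2-fluorophenyl in place of 3,4,5-trimethoxyphenyl, which gives a 1.2-fold higher number from compound 1 to compound 3 (0.09 log units; within the scatter), so each of these exchanges taken alone stays inside the scatter, something the first two compounds could not show as they differ in more than one place. No measurement is available that would explain these results.

Still open, going by these compounds, is whether a group of a different kind at this position, such as an amine or a carboxylic acid, would move the number beyond the scatter. The compounds shown also leave open how the shared core behaves with a longer chain in place of the acetamide hydrogen-bearing end of the sulfonyl group.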